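The compounds below may be only part of what the source reports. "The series", "measured", "known", "first", "only" and "open" are said of these compounds alone.

Of the compounds shown here, three sharing one core have been tested in a functional assay on MCF7 cells (Homo sapiens) for antiproliferative activity, read by MTT assay, with a stated time of 48 h; a higher number here means a weaker inhibitor, a lower number a stronger inhibitor: compound 1 (`COc1cc(-c2cccc3nc(-c4ccc(Br)cc4)oc23)cc(OC)c1OC`), compound 2 (`COc1cc(-c2cccc3nc(-c4cccc(O)c4)oc23)cc(OC)c1OC`) and compound 3 (`COc1ccc(-c2nc3c(-c4cc(OC)c(OC)c(OC)c4)cccc3o2)cc1OC`). Compound 3 gives > 25000 nM, which is a limit of the assay and not a number. Compound 1 gives > 25000 nM, also a limit. Compound 2 gives > 25000 nM, again a limit. Compound 3 therefore stands with the other two at the limit of > 25000 nM in this assay, at which 3 of the 3 values shown sit.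

Compound 4 (`COc1cc(OC)cc(-c2nc3c(-c4cc(OC)c(OC)c(OC)c4)cccc3o2)c1`) has the same atoms as compound 3, joined differently. It carries 3,5-dimethoxyphenyl in place of 3,4-dimethoxyphenyl, on an aromatic carbon of a five-membered aromatic ring with 1 nitrogen and 1 oxygen (3,5-dimethoxyphenyl in place of 3,4-dimethoxyphenyl on an aromatic carbon).

Among the compounds with values here, the one measured step, a step that the two limits leave unreadable from compound 1 to compound 2, also exchanges one substituted phenyl group for another, but both of its ends are limits, so it offers no size to carry over. No step beyond the scatter is therefore expected in this assay, in either direction, and the assay will probably again report only a limit. This expectation starts from compound 3 at its limit of > 25000 nM. The estimated step is a number no higher from compound 3 to compound 4 (the limit leaves the size open). Compound 4 is expected at about 25000 nM, with an estimated range from 9000 nM to 50000 nM.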

Compound 4, half-maximal inhibitory concentration: > 25000 nM
Compound 4: no number, only a limit; the forecaster's own chance of this, stated with the estimate: 75%; the middle value lies on the limit itself.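

In this assay compound 4 gives > 25000 nM, which is a limit of the assay and not a number. Compound 3 also stands at a limit, so no step can be read between compound 3 and compound 4: the limit of > 25000 nM in this assay, at which 4 of the 4 values shown sit. The compounds shown leave open whether any change on the shared core would give a measurable value.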